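Swapping the para substituent in a phosphodiesterase series

A few compounds are considered here, and "the series" means these few. Any claim that something is new, unique, unknown or untested is made for them only; others in the source may bear on it.

Three amides sharing one core were measured in an in vitro assay on Sf21 cells for inhibition of high affinity 3',5'-cyclic-AMP phosphodiesterase 7A (Homo sapiens), read by scintillation proximity assay, with a stated time of 30 min; on this read-out lower numbers stand for stronger inhibition and higher numbers for weaker inhibition. Compound 1 `CCN(CC)c1ccc(NC(=O)c2cn(Cc3c(F)cccc3F)c3ccc(=O)[nH]c3c2=O)cc1` gives 46 nM, compound 2 `O=C(Nc1ccc(C(=O)N2CCOCC2)cc1)c1cn(Cc2c(F)cccc2F)c2ccc(=O)[nH]c2c1=O` gives 188 nM, and compound 3 `CS(=O)(=O)c1ccc(NC(=O)c2cn(Cc3c(F)cccc3F)c3ccc(=O)[nH]c3c2=O)cc1` gives 27 nM, the lowest of the three numbers, with compound 1 nearest and compound 2 furthest. The change now considered, to compound 4 `O=C(Nc1ccc(OC(F)F)cc1)c1cn(Cc2c(F)cccc2F)c2ccc(=O)[nH]c2c1=O`, is difluoromethoxy in place of methylsulfonyl on an aromatic carbon. The steps at this same position bear on it: a 1.7-fold lower number from compound 1 to compound 3 (0.23 log units; within the scatter) and a 7.0-fold lower number from compound 2 to compound 3 (0.84 log units; beyond the scatter), so the group there moves the number only modestly. Compound 4 is therefore expected to differ little from compound 3, a 1.9-fold higher number from compound 3 to compound 4 (0.27 log units; within the scatter), within or only just beyond the scatter. The estimate for compound 4 in this assay is 50 nM, ranging from 17 nM to 150 nM.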

Compound 4, half-maximal inhibitory concentration: 71 nM
Compound 4: the middle estimate sits 1.4-fold (0.15 log units) below what was measured; the range from low to high includes it.
By their numbers in this assay, from the lowest: compounds 3, 1 and 4 (each within the scatter of the next, the first and the last beyond it); then compound 2.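

With the same count of heavy atoms on either side of the change, the swap from methylsulfonyl to difluoromethoxy still gives a 2.6-fold higher number from compound 3 to compound 4 (0.42 log units; beyond the scatter) in this assay, so that count alone does not set the number at this position. The new group also gives a 1.5-fold higher number from compound 1 to compound 4 (0.19 log units; within the scatter) and a 2.6-fold lower number from compound 2 to compound 4 (0.42 log units; beyond the scatter), placing compound 4 with the diethylamino compound rather than the (morpholin-4-yl)carbonyl compound. Nothing available explains these steps. The compounds shown leave open where a plain methoxy group, with no fluorine, or a chlorine atom would fall at this same place.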